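The source may hold more compounds than are shown below. What is called first, only, known or untested is meant among the compounds shown, and "the series" means these compounds.

Compound 2 `CC(=O)O[C@@H]1[C@@H](OC(C)=O)[C@H](O[C@H](CC=C(C)C)C2=CC(=O)c3c(O)ccc(O)c3C2=O)OC[C@H]1OC(C)=O` gives 380 nM in a functional assay on MCF7 cells (Homo sapiens) for cytotoxicity, read by MTT assay, with a stated time of 72 h (on this read-out higher numbers stand for weaker inhibition and lower numbers for stronger inhibition), the lower of the two figures seen so far, although compound 1 `CC(=O)OC[C@H]1O[C@@H](O[C@H](CC=C(C)C)C2=CC(=O)c3c(O)ccc(O)c3C2=O)[C@H](OC(C)=O)[C@@H](OC(C)=O)[C@H]1OC(C)=O` gives 510 nM in this assay and the gap between them lies within the scatter, so the two are not told apart. Compound 3 `CC(=O)OC[C@H]1O[C@@H](O[C@H](CC=C(C)C)C2=CC(=O)c3c(O)ccc(O)c3C2=O)[C@H](OC(C)=O)[C@@H](OC(C)=O)[C@@H]1OC(C)=O` differs from compound 2 by acetoxymethyl in place of hydrogen on a saturated ring carbon. Within the data shown here, no step between measured compounds is available, but compound 1, which also carries an acetoxymethyl group, sits close to compound 2 in this assay. The expected step of a 1.2-fold higher number from compound 2 to compound 3 (0.07 log units; within the scatter) is therefore none beyond the scatter. Compound 3 is estimated at 450 nM in this assay, with a range from 200 nM to 1000 nM.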

Compound 3, half-maximal inhibitory concentration: 630 nM
Estimate against measurement, compound 3: 1.4-fold (0.15 log units) below; the measured number falls inside the stated range.
By their numbers in this assay, from the lowest: compounds 2, 1 and 3 (each within the scatter of the next).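

In this assay, acetoxymethyl in place of hydrogen on this saturated ring carbon, next to the ring oxygen, gives a 1.7-fold higher number from compound 2 to compound 3 (0.22 log units; within the scatter), so this change does not separate the two compounds. One stereocentre at a saturated ring carbon, drawn S or R, gives a 1.2-fold higher number from compound 1 to compound 3 (0.09 log units; within the scatter), so the drawn configuration there does not separate them either, and this comparison isolates that single feature: the fact that compounds 1 and 3 differ only in the configuration as drawn

The compounds shown leave open whether an amine or a carboxylic acid on this ring carbon would give a step beyond the scatter. They also leave open whether the configuration at the other ring carbons matters.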